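Ortho-chloro on the benzylsulfanyl arm of the nitrophenyl analogue

The source may hold more compounds than are shown below. What is called first, only, known or untested is meant among the compounds shown, and "the series" means these compounds.

The series shares one core and varies two arms. Compound 1 `COc1ccc(C2N=C(SCc3ccccc3)NC(C)=C2C(=O)Nc2ccc(F)cc2)cc1OC` in a functional assay on the whole organism (artery, strain albino) with Rattus norvegicus as the target, with a stated time of 60 min, at a dose of 10 mg/kg by the oral route (on this read-out higher numbers stand for more inhibition at the one dose given (going by the name of the read-out) and lower numbers for less inhibition), gives 6.2%. Compound 2 `COc1ccc(C2N=C(SCc3ccccc3Cl)NC(C)=C2C(=O)Nc2ccc(F)cc2)cc1OC` in this assay gives 11.8%, and the change a number 5.6 percentage points higher from compound 1 to compound 2 (within the scatter) stays within the scatter. Compound 3 `CC1=C(C(=O)Nc2ccc(F)cc2)C(c2ccc([N+](=O)[O-])cc2)N=C(SCc2ccccc2)N1` in this assay gives 12.3%, with a number 6.1 percentage points higher from compound 1 to compound 3 (within the scatter) also within the scatter. Compound 3 therefore stands at the top of the three numbers, yet neither its gap to compound 2 nor its gap to compound 1 reaches beyond the scatter, so no ordering among the three can be claimed.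

Compound 4 `CC1=C(C(=O)Nc2ccc(F)cc2)C(c2ccc([N+](=O)[O-])cc2)N=C(SCc2ccccc2Cl)N1` is not yet measured. It differs from compound 3 by chloro in place of hydrogen on an aromatic carbon. Going by the values given here, the one measured step of this same kind is a number 5.6 percentage points higher from compound 1 to compound 2 (within the scatter), made on the dimethoxyphenyl analogue; it did not exceed the scatter. Carried onto compound 3, the expectation for this assay is a step of about the same small size, a number 3.7 percentage points higher from compound 3 to compound 4 (within the scatter), upward in sign but not clearly beyond the scatter. Compound 4 is accordingly expected to give 16% in this assay, with a plausible range from 5% to 28%.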

Compound 4, a percentage reported as inhibition, in the whole organism at one dose (the size of the read-out at that dose, not a potency): 6.2%
For compound 4 the middle estimate is 9.8 percentage points above the measured one, and the stated range covers the measured number.
By their numbers in this assay, from the lowest: compounds 1, 4, 2 and 3 (each within the scatter of the next).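

Chloro in place of hydrogen, ortho to a large group, now has a second reading in this assay, and on the nitrophenyl analogue it gives a number 6.1 percentage points lower from compound 3 to compound 4 (within the scatter), while on the dimethoxyphenyl analogue it gave a number 5.6 percentage points higher from compound 1 to compound 2 (within the scatter). The signs of these two steps differ, but the gap between them does not separate the cores: the same change on two cores in this assay, a number 5.6 percentage points higher (within the scatter) from compound 1 to compound 2 and a number 6.1 percentage points lower (within the scatter) from compound 3 to compound 4, 11.7 percentage points apart, within the scatter of two such steps. Going by these compounds alone, the exchange of 3,4-dimethoxyphenyl for 4-nitrophenyl, read for the first time with the 2-chlorobenzyl arm in place, gives a number 5.6 percentage points lower from compound 2 to compound 4 (within the scatter), and its two readings behave in the same way: the same change on two cores in this assay, a number 6.1 percentage points higher (within the scatter) from compound 1 to compound 3 and a number 5.6 percentage points lower (within the scatter) from compound 2 to compound 4, 11.7 percentage points apart, within the scatter of two such steps.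

Neither change therefore has a direction that can be stated for this series, and any dependence of one arm on the other remains unsupported. Still open, going by these compounds, is whether a methoxy group or an amine on the same aromatic ring, or a longer chain in place of the benzyl group on sulfur, would give a step beyond the scatter in this assay.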